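Ester variation at a shared core: cytotoxicity expected to stay absent

This account rests on a few compounds, and the source may have more. Where it says the series, first, only, none or still open, it means among the compounds named here.

Compound 1: `Cc1cn([C@H]2CO[C@@H](COC(=O)C3CCCCC3)O2)c(=O)[nH]c1=O` — > 100000 nM
Compound 2: `CC(=O)OC[C@@H]1OC[C@H](n2cc(C)c(=O)[nH]c2=O)O1` — > 100000 nM

Compound 1, with the structure `Cc1cn([C@H]2CO[C@@H](COC(=O)C3CCCCC3)O2)c(=O)[nH]c1=O`, was examined in an ADME assay on PBMC cells (Homo sapiens) for cytotoxicity, read by MTT assay, with a stated time of 3 days (a lower number here means a stronger inhibitor, a higher number a weaker inhibitor), and gives > 100000 nM, which is a limit of the assay rather than a measured number. Compound 2, with the structure `CC(=O)OC[C@@H]1OC[C@H](n2cc(C)c(=O)[nH]c2=O)O1`, gives in this assay > 100000 nM, again a limit. The step that the two limits leave unreadable from compound 1 to compound 2 is therefore not readable, since both ends sit at a limit. All that is shown is summarised by the limit of > 100000 nM in this assay, at which 2 of the 2 values shown sit.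

Compound 3, with the structure `Cc1cn([C@H]2CO[C@@H](COC(=O)C(C)(C)C)O2)c(=O)[nH]c1=O`, is not yet measured. It differs from compound 1 by tert-butyl in place of cyclohexyl on a carbonyl carbon. Among the compounds with values here, the only measured step that bears on this kind of change is the one from compound 1 to compound 2, and its size cannot be read. No further information points to a change in this assay beyond the scatter, so compound 3 is expected to remain at the limit as well. The expected step is a step that the limit leaves unreadable from compound 1 to compound 3, which is estimated as no movement beyond the scatter. Compound 3 is expected to give 150000 nM, with a range from 60000 nM to 400000 nM.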

Compound 3, half-maximal inhibitory concentration: > 100000 nM
Compound 3: no number, only a limit; the forecaster's own chance of this, stated with the estimate: 90%; the middle value lies beyond the limit too.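

Compound 3 gives no number in this assay but a limit, > 100000 nM as printed. Within the data shown here, no step among compound 1, compound 2 and compound 3 can be read: the limit of > 100000 nM in this assay, at which 3 of the 3 values shown sit. The compounds shown leave open whether the cyclohexyl, methyl and tert-butyl esters differ at all in this assay and at what concentration, if any, each would show an effect.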